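Methyl on the Core: Expected Solubility of Compound 3

The source may report more compounds than this note shows. Statements on the series, on what has been measured and on what is new or still open speak of the compounds shown alone.

Compound 1 `CCCS(=O)(=O)Nc1ccc(F)c(C(=O)Nc2cnc3[nH]ncc3c2)c1F`: 150 ug/mL
Compound 2 `CCCS(=O)(=O)Nc1ccc(Cl)c(C(=O)Nc2cnc3[nH]ncc3c2)c1F`: 48 ug/mL

In a physicochemical assay for solubility, read by HPLC, in phosphate buffer, with a stated time of 24 h, at pH 7.4 (on this read-out higher numbers stand for higher solubility and lower numbers for lower solubility), compound 1 stands highest of the two numbers measured; its nearest neighbour is compound 2, and the step of a 3.1-fold lower number from compound 1 to compound 2 (0.49 log units; beyond the scatter) runs downward. Compound 3 `CCCS(=O)(=O)Nc1ccc(F)c(C(=O)Nc2cnc3[nH]nc(C)c3c2)c1F` differs from compound 1 by methyl in place of hydrogen on an aromatic carbon. Among the compounds with values here, no measured step touches this position, so the one known step does not bear directly on it. A single added methyl is expected to move this assay only modestly downward, and the estimated step of a 1.9-fold lower number from compound 1 to compound 3 (0.27 log units; within the scatter) reflects that. Compound 3 is therefore expected to give about 80 ug/mL, within the range 30 ug/mL to 200 ug/mL.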

Compound 3, solubility: 740 ug/mL
Compound 3: middle estimate off by 9.3-fold (0.97 log units), on the low side; measured number above the stated range.
By their numbers in this assay, from the lowest: compound 2; then compound 1; then compound 3.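

In this assay, within the data shown here, methyl in place of hydrogen on an aromatic carbon of the five-membered aromatic ring gives a 4.9-fold higher number from compound 1 to compound 3 (0.69 log units; beyond the scatter) and so shows that this position, which the earlier compounds left unchanged, can carry the number upward. Among these compounds, the only earlier step, chloro in place of fluoro, went the other way and at another place. Nothing measured here explains the rise.

On these data alone, whether an ethyl group, a longer chain or an amine on this same carbon would go the same way stays open. So does whether methyl would raise the number on compound 2 as well.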